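Swapping an Ethyl for an Ester on the Aryl Ketone

The source may hold more compounds than are shown below. What is called first, only, known or untested is meant among the compounds shown, and "the series" means these compounds.

Compound 3 `CCc1ccc(C(=O)/C=C/c2ccc3c(c2)B(O)OC3)cc1` is one of three analogues built on a shared core. In a functional assay on MDA-MB-231 cells (Homo sapiens) for cytotoxicity, read by MTT assay, with a stated time of 48 h (on this read-out lower numbers stand for stronger inhibition and higher numbers for weaker inhibition), compound 3 gives 9800 nM, the lower of the two numbers recorded, although compound 1 `O=C(/C=C/c1ccc2c(c1)B(O)OC2)c1cccnc1` gives 11400 nM, within the scatter of that figure. Compound 2 `Cn1cccc1C(=O)/C=C/c1ccc2c(c1)B(O)OC2` reaches only the limit > 100000 nM in this assay. For the measured compounds named here, the single measured step, an at least 8.7-fold higher number from compound 1 to compound 2 (0.94 log units; beyond the scatter), replaces the whole ring on the carbonyl carbon and so says little about changing a substituent on an intact phenyl ring. Compound 4 `CCOC(=O)c1ccc(C(=O)/C=C/c2ccc3c(c2)B(O)OC3)cc1` differs from compound 3 by ethoxycarbonyl in place of ethyl on an aromatic carbon. Going by the values given here, with no comparable step measured, compound 4 is expected to stay near that footing. The expected step is a 1.1-fold lower number from compound 3 to compound 4 (0.04 log units; within the scatter). Compound 4 is therefore estimated at 9000 nM, with a range from 3000 nM to 30000 nM.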

Compound 4, half-maximal inhibitory concentration: 13000 nM
Estimate against measurement, compound 4: 1.4-fold (0.16 log units) below; low and high end bracket the measured number.
By their numbers in this assay, from the lowest: compounds 3, 1 and 4 (each within the scatter of the next). At a limit, above all of these: compound 2.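

In this assay, ethoxycarbonyl in place of ethyl on the aromatic carbon para to a large group gives a 1.3-fold higher number from compound 3 to compound 4 (0.12 log units; within the scatter), so the two compounds cannot be told apart. For the compounds shown here, this is the first look at a single substituent on an intact phenyl ring, and here a group with more heavy atoms and hydrogen-bond acceptors is accommodated without a step beyond the scatter. Nothing shown bears on why these two numbers agree. From the compounds shown here alone, whether a carboxylic acid, an amine or a longer chain at this position would read the same remains open. So does whether any group here can move the number beyond the scatter.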